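Acetyl for hydrogen on a weakly antiproliferative core

The source may report more compounds than this note shows. Statements on the series, on what has been measured and on what is new or still open speak of the compounds shown alone.

Measured compounds:
compound 1 `COc1cc(-c2cc(CO[C@@H]3O[C@H](CSc4ncn[nH]4)[C@H]4OC5(CCCC5)O[C@@H]34)on2)cc(OC)c1OC` gives 74000 nM
compound 2 `Nc1nnc(SC[C@H]2O[C@@H](OCc3noc(-c4ccc(Cl)cc4)n3)[C@@H]3OC4(CCCC4)O[C@@H]32)s1` gives 15000 nM
compound 3 `O=[N+]([O-])c1ccc(-c2nc(CO[C@@H]3O[C@H](CO)[C@H]4OC5(CCCC5)O[C@@H]34)no2)cc1` gives 41000 nM

In a functional assay on WiDr cells (Homo sapiens) for antiproliferative activity, read by sulforhodamine B assay, with a stated time of 48 h (a lower number here means a stronger inhibitor of growth, a higher number a weaker inhibitor of growth), compound 3 gives 41000 nM, the second highest of the three numbers. Compound 1 gives 74000 nM, which lies within the scatter of compound 3, so the two cannot be told apart. Compound 2 gives 15000 nM, a lower number than compound 3 and beyond the scatter; compound 2 differs from compound 3 in more than one place, so only the two values themselves can be compared.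

Compound 4 `CC(=O)OC[C@H]1O[C@@H](OCc2noc(-c3ccc([N+](=O)[O-])cc3)n2)[C@@H]2OC3(CCCC3)O[C@@H]21` has not been measured in this assay. It differs from compound 3 by acetyl in place of hydrogen on an oxygen on a saturated carbon. Among the compounds with values here, no measured pair in this set shows a step of this kind, so there is no direct precedent. All three measured compounds sit in the same weakly active region, and compound 1, which carries a larger replacement at the same position, gives 74000 nM, close to compound 3. The expectation for the step from compound 3 to compound 4 is therefore small, with no clear direction, and is estimated as a 1.1-fold lower number from compound 3 to compound 4 (0.03 log units; within the scatter). Compound 4 is expected to give about 38000 nM, with a range from 13000 nM to 110000 nM.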

Compound 4, concentration for 50% growth inhibition: 36000 nM
Compound 4: the middle estimate sits 1.1-fold (0.02 log units) above what was measured; the measured number falls inside the stated range.
By their numbers in this assay, from the lowest: compound 2; then compounds 4, 3 and 1 (each within the scatter of the next, the first and the last beyond it).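

In this assay, the change from hydroxymethyl to acetoxymethyl gives a 1.1-fold lower number from compound 3 to compound 4 (0.06 log units; within the scatter) and so stays within the scatter. Within the data shown here, this is the first reading of a single change at this position, since compounds 1 and 2 each differ from compound 3 in more than one place and could not isolate it. It shows that, on this core, the free hydroxy hydrogen can give way to an acetyl group, with its three heavy atoms and its added carbonyl, without a change that this assay can resolve, and no separate measurement bears on this result.

The compounds shown leave open whether this tolerance extends to other replacements at this oxygen or carbon, such as a longer acyl chain, an amine or a carboxylic acid, any of which might move the number beyond the scatter. Among these compounds, they also leave open whether the same acetyl change would read the same way on a compound carrying the other parts of compound 2, the one member of the set whose value lies beyond the scatter of compound 3.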